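The source may report more compounds than this note shows. Statements on the series, on what has been measured and on what is new or still open speak of the compounds shown alone.

Measured compounds:
- compound 1, `O=C(NCCCNc1nc(Nc2cnn(C3CCOCC3)c2)ncc1C1CC1)C1CCC1`: 2 nM
- compound 2, `O=C(NCCCNc1nc(NCc2ccc(F)cc2)ncc1C1CC1)c1cccs1`: > 10000 nM

In an assay on isolated protein for inhibition of serine/threonine-protein kinase TBK1 (Homo sapiens) (on this read-out higher numbers stand for weaker inhibition and lower numbers for stronger inhibition), compound 1 gives 2 nM. Compound 2 gives no number here but only a limit of the assay, > 10000 nM, which is the limit of > 10000 nM in this assay, at which 1 of the 2 values shown sits. Compound 1 thus stands as the single actual number shown, and it is a strong inhibitor; the one other value is a limit, so the two cannot be compared as numbers, and no measured pair differs in just one place.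

Compound 3, `O=C(NCCCNc1nc(Nc2cnn(C3CC3)c2)ncc1C1CC1)C1CCC1`, has not yet been measured. Compared with compound 1 it changes in one spot: cyclopropyl in place of oxan-4-yl on an aromatic nitrogen. The rest of the molecule, including the amide, the chain and the shared core of compound 1, is kept. Because the step from compound 1 to compound 3 is not measured, the size of the step in this assay is a guess: the expectation is a small loss or a change that stays within the scatter. Compound 3 is expected to give about 4 nM, with a range from 1 nM to 15 nM. This expected result corresponds to a step of a 2.0-fold higher number from compound 1 to compound 3 (0.30 log units; within the scatter).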

Compound 3, half-maximal inhibitory concentration: 10 nM
The estimate for compound 3 lay 2.5-fold (0.40 log units) below the measured number; the range from low to high includes it.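

In this assay, the swap of oxan-4-yl for cyclopropyl on the aromatic nitrogen gives a 5.0-fold higher number from compound 1 to compound 3 (0.70 log units; beyond the scatter) and so shows that the group at this position affects the read-out, by a modest amount. The six-membered ring is not required for strong inhibition, since compound 3 still gives 10 nM in this assay, but the step replaces a larger ring that contains an oxygen with a smaller ring of carbon only, so ring size and the oxygen change together and this single comparison cannot separate them. Nothing measured here explains why the number rises.

A cyclohexyl group, which keeps the six-membered ring but has carbon only, would help to separate the two changes, and a piperidin-4-yl group, with a ring nitrogen in place of the oxygen, remains an open case at this position as well. Compound 2 has only a limit as its value and differs from compound 1 in more than one place, which leaves open how the other parts of the molecule contribute.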